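A few compounds are considered here, and "the series" means these few. Any claim that something is new, unique, unknown or untested is made for them only; others in the source may bear on it.

For the measured compounds named here, in a functional assay on MCF7 cells (Homo sapiens) for inhibition, read by MTT assay, with a stated time of 72 h (a lower number here means a stronger inhibitor, a higher number a weaker inhibitor), compound 3 (`C#CCSc1nc2nc(C)cc(Nc3cc(-c4ccccc4)[nH]n3)n2n1`) gives 21800 nM as the higher of the two true numbers so far. The other is compound 2 (`Cc1cc(Nc2cc(-c3ccccc3)[nH]n2)n2nc(SCCCc3ccccc3)nc2n1`) at 3900 nM in the same test. Compound 1 (`Cc1cc(Nc2cc(-c3ccccc3)[nH]n2)n2nc(SCC3CCCCC3)nc2n1`) reads > 50000 nM here, and that value is a limit of the assay, not a number.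

Compound 4 (`COc1ccc(CSc2nc3nc(C)cc(Nc4cc(-c5ccccc5)[nH]n4)n3n2)cc1`) carries 4-methoxyphenyl in place of ethynyl on a saturated chain carbon bound to a sulfur. Going by the values given here, no measured step makes this exact change, but the same place was varied in the other compounds. The steps there were sizeable: (an at least 12-fold lower number from compound 1 to compound 2 (1.10 log units; beyond the scatter)) and (a 5.6-fold higher number from compound 2 to compound 3 (0.75 log units; beyond the scatter)). Compound 4 brings a six-membered aromatic ring to this place, as compound 2 does with 3900 nM in its phenethyl group, so a move toward a lower number is expected. Compound 1 goes against any simple rule that a larger group helps, so the expectation stays cautious. In this assay the expected change is modest: a 2.4-fold lower number from compound 3 to compound 4 (0.38 log units; beyond the scatter). The estimate for compound 4 is 9000 nM with an expected range from 3000 nM to 30000 nM.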

Compound 4, half-maximal inhibitory concentration: 4020 nM
Compound 4: the middle estimate sits 2.2-fold (0.35 log units) above what was measured, within the range that was stated.
By their numbers in this assay, from the lowest: compounds 2 and 4 (each within the scatter of the next); then compound 3. At a limit, above all of these: compound 1.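

In this assay, the step of a 5.4-fold lower number from compound 3 to compound 4 (0.73 log units; beyond the scatter) shows that a six-membered aromatic ring of carbon only, brought to this saturated chain carbon bound to a sulfur, goes with a clearly lower number than ethynyl does. The two aromatic groups shown cannot be told apart, given a 1.0-fold higher number from compound 2 to compound 4 (0.01 log units; within the scatter), so compounds 2 and 4 now both sit below the two compounds without an aromatic ring. Against cyclohexyl, whose value is a limit and not a number, the change gives an at least 12-fold lower number from compound 1 to compound 4 (1.09 log units; beyond the scatter), so ring size alone does not set the result.

A plain benzyl group at this place would show whether the methoxy contributes anything. A pyridylmethyl group or a benzyl group bearing an amine or a carboxylic acid would test how much change the ring tolerates.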